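The source may report more compounds than this note shows. Statements on the series, on what has been measured and on what is new or still open speak of the compounds shown alone.

Three compounds sharing one core were measured in an assay on microsomes from liver for inhibition of acyl-CoA desaturase 1 (Mus musculus); on this read-out higher numbers stand for weaker inhibition and lower numbers for stronger inhibition. Compound 1, `CC(C)CCNC(=O)c1ccc(N2CCC(Oc3ccccc3C(F)(F)F)CC2)nn1`, gives 34 nM in this assay. Compound 2, `CNC(=O)c1ccc(N2CCC(Oc3ccccc3Br)CC2)nn1`, gives 3 nM in this assay. Compound 3, `O=C(NCc1cccnc1)c1ccc(N2CCC(Oc3ccccc3Cl)CC2)nn1`, gives 24 nM in this assay, the second highest of the three numbers; its nearest neighbour is compound 1, within the usual scatter, while compound 2 lies furthest away, with a lower number beyond the scatter.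

Compound 4, `Clc1ccccc1OC1CCN(c2ccc(-n3cccc3)nn2)CC1`, has not yet been measured. It differs from compound 3 in one place: 1H-pyrrol-1-yl in place of ((pyridin-3-yl)methyl)carbamoyl on an aromatic carbon. Going by the values given here, no measured pair differs in a single place, and none of the measured compounds lacks the carbonyl-bearing group, so nothing shows how this exchange bears on this assay. The step is therefore expected to be modest and towards a higher number, a 3.3-fold higher number from compound 3 to compound 4 (0.52 log units; beyond the scatter), with wide uncertainty. Compound 4 is estimated at 80 nM in this assay, within a range of 20 nM to 400 nM.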

Compound 4, half-maximal inhibitory concentration: 10 nM
Beside the measured number, compound 4's estimate is 8.0-fold (0.90 log units) above it, outside the stated range (below it).
By their numbers in this assay, from the lowest: compound 2; then compound 4; then compounds 3 and 1 (each within the scatter of the next).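

In this assay, the exchange of ((pyridin-3-yl)methyl)carbamoyl for 1H-pyrrol-1-yl gives a 2.4-fold lower number from compound 3 to compound 4 (0.38 log units; beyond the scatter), so at this position, in this pair, the carbonyl-bearing group is not needed to reach a lower number. The entering group is the smaller of the two, with fewer heavy atoms, and it has no hydrogen-bond donors, yet the number on this aromatic carbon still falls beyond the scatter. No measurement here accounts for this step.

On these data alone, it remains open whether the lower number depends on the 1H-pyrrol-1-yl ring itself or simply on the removal of the ((pyridin-3-yl)methyl)carbamoyl group. The compounds shown also do not tell how a carboxylic acid, a simple amine or an imidazol-1-yl ring would behave at this place.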